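The source may hold more compounds than are shown below. What is called first, only, known or untested is meant among the compounds shown, and "the series" means these compounds.

Measured so far in a functional assay on T47D cells (Homo sapiens) for inhibition, read by sulforhodamine B assay, with a stated time of 48 h; on this read-out higher numbers stand for weaker inhibition of growth and lower numbers for stronger inhibition of growth:
compound 1, `CC(=O)OC/C(=C/c1ccc(Cl)cc1Cl)C(=O)c1ccccc1`, gives 20000 nM
compound 2, `CC(=O)OC/C(=C/c1ccc(Cl)cc1)C(=O)c1ccc(Cl)cc1`, gives 12000 nM

These two numbers lie within the usual scatter of one another, so compound 2 and compound 1 cannot be told apart in this assay, and compound 2 stands as one of two similar results rather than apart from the other.

Compound 3, `CC(=O)OC/C(=C/c1ccc(Cl)cc1Cl)C(=O)c1ccc(Cl)cc1`, has not yet been measured. It differs from compound 2 in one place: chloro in place of hydrogen on an aromatic carbon. Read one bond further out, this turns 4-chlorophenyl into 2,4-dichlorophenyl, the group that compound 1 also carries. Among the compounds with values here, no pair of measured compounds differs by exactly this change, so there is no measured step to lean on. With compound 1 and compound 2 within the scatter of each other, the expected step of a 1.1-fold higher number from compound 2 to compound 3 (0.03 log units; within the scatter) is none beyond the scatter. Compound 3 is therefore estimated at 13000 nM, with a range from 5000 nM to 32000 nM.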

Compound 3, concentration for 50% growth inhibition: 20000 nM
Beside the measured number, compound 3's estimate is 1.5-fold (0.19 log units) below it; the measured number falls inside the stated range.
By their numbers in this assay, from the lowest: compounds 2, 1 and 3 (each within the scatter of the next).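

In this assay, chloro in place of hydrogen on an aromatic carbon, ortho to a large group, turns 4-chlorophenyl into 2,4-dichlorophenyl and gives a 1.7-fold higher number from compound 2 to compound 3 (0.22 log units; within the scatter) and so leaves the two compounds indistinguishable. The same kind of exchange on the other aromatic ring gives no change at the digits printed from compound 1 to compound 3 (within the scatter) and so, in these compounds, a chloro added at either place produces no step beyond the scatter. No measurement shown here offers an explanation for these results.

As far as these compounds go, whether a different group at the ortho position, such as an amine or a methoxy group, would move the number beyond the scatter remains open. So does whether a group other than chloro would behave differently on the other aromatic ring.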